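Compound 3 to compound 4: a longer chain on nitrogen

The compounds below may be only part of what the source reports. "The series", "measured", "known", "first", "only" and "open" are said of these compounds alone.

In a functional assay on MDA-MB-435 cells (Homo sapiens) for cytotoxicity, read by MTT assay, with a stated time of 72 h (a higher number here means a weaker inhibitor, a lower number a stronger inhibitor), compound 1 (`O=C(NCc1ccc(F)cc1)c1nc(Br)c2cccnc2c1NCCCNc1c(C(=O)NCc2ccc(F)cc2)nc(Br)c2cccnc12`) reads > 20000 nM as a limit of the assay and not a number. Among the measured compounds shown here, compound 2 (`CN(C)CCCNc1c(C(=O)NCc2ccc(F)cc2)nc(Br)c2cccnc12`) gives 7000 nM and is the only true number so far. Compound 3 (`C[C@@H](CO)Nc1nc(C(=O)NCc2ccc(F)cc2)c(O)c2ncccc12`) reads > 20000 nM as a limit too, so it stands with the limit of > 20000 nM in this assay, at which 2 of the 3 values shown sit, and has no number of its own.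

Compound 4 (`O=CNCCCCCCNc1nc(C(=O)NCc2ccc(F)cc2)c(O)c2ncccc12`) carries 6-(formylamino)hexyl in place of 1-(hydroxymethyl)ethyl on a nitrogen on an aromatic ring and the defined stereocentre goes with the group that leaves. For the measured compounds named here, no measured pair isolates this change. Going by the values given here, compound 2 at 7000 nM is the only guide to what a true number looks like. The expected at least 1.6-fold lower number from compound 3 to compound 4 (0.22 log units; that floor lies within the scatter) in this assay is small and toward a stronger inhibitor, and another limit reading is quite possible. For compound 4 the estimated value is 12000 nM within an expected range of 4000 nM to 30000 nM for this measurement.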

Compound 4, half-maximal inhibitory concentration: 16000 nM
Compound 4: middle estimate off by 1.3-fold (0.12 log units), on the low side; measured number inside the range.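

In this assay, the step with 6-(formylamino)hexyl in place of 1-(hydroxymethyl)ethyl is an at least 1.2-fold lower number from compound 3 to compound 4 (0.09 log units; that floor lies within the scatter), so this change gives a readable number but does not establish a real gain. Compound 3 holds a limit and not a number, and the true size of the step stays unknown because of that reading: the limit of > 20000 nM in this assay, at which 2 of the 4 values shown sit.

The nitrogen on an aromatic ring carries this longer chain without a defined stereocentre, and compound 4 stays on the scale at 16000 nM. Still open, on these data alone, is whether the chain length, the formylamino group or the loss of the stereocentre accounts for that reading. Also open, as far as these compounds go, is how a hexyl chain carrying a primary amine or a carboxylic acid in place of formylamino would read.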